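This account rests on a few compounds, and the source may have more. Where it says the series, first, only, none or still open, it means among the compounds named here.

Measured in a functional assay on A-375 cells (Homo sapiens) for activation, with a stated time of 3 days; on this read-out higher numbers stand for an effect only at larger amounts of compound and lower numbers for an effect already at smaller amounts:
- Compound 1 `O=C(Nc1ccc(-c2cscn2)cc1)C1CN(Cc2ccc(F)c(F)c2)C1`: > 20000 nM, a limit of the assay
- Compound 2 `O=C(Nc1ccc2scnc2c1)C1CCCN(Cc2ccc(F)c(F)c2)C1`: > 20000 nM, a limit of the assay
- Compound 3 `O=C(Nc1ccc(-c2cccnc2)cc1)C1CCCN(Cc2ccc(F)c(F)c2)C1`: 1060 nM

Among these three compounds, only compound 3 gives an actual number, 1060 nM. The rest of the picture is the limit of > 20000 nM in this assay, at which 2 of the 3 values shown sit, so the data offer no second number to compare it with.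

The next compound, compound 4 `O=C(Nc1ccc(-c2ccn[nH]2)cc1)C1CCCN(Cc2ccc(F)c(F)c2)C1`, keeps everything in compound 3 except one group: 1H-pyrazol-5-yl in place of pyridin-3-yl on an aromatic carbon. The 1H-pyrazol-5-yl takes the place of pyridin-3-yl on the same aromatic carbon, para to a large group.

Among the measured compounds shown here, no measured pair in the set shows a swap of this kind, so any expectation for this assay rests on compound 3 alone and stays loose. A modest shift toward a higher number is expected, and it may not clear the usual scatter. The estimated change is a 1.4-fold higher number from compound 3 to compound 4 (0.15 log units; within the scatter). For compound 4 the expected value is 1500 nM, with an estimated range from 350 nM to 7000 nM.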

Compound 4, half-maximal effective concentration: 580 nM
Compound 4: middle estimate off by 2.6-fold (0.41 log units), on the high side; measured number inside the range.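

In this assay, among the compounds shown here, 1H-pyrazol-5-yl in place of pyridin-3-yl on this aromatic carbon, para to a large group, gives a 1.8-fold lower number from compound 3 to compound 4 (0.26 log units; within the scatter) as the first step in the set between two actual numbers. The position therefore takes a five-membered aromatic ring with 2 hetero atoms and 1 hydrogen-bond donor as well as the six-membered ring, and the two compounds cannot be told apart on this read-out. For the compounds shown here, the only further information at hand concerns the limit of the assay and gives no cause for this step.

Going by these compounds, it stays open how an amine or a carboxylic acid would read at this place on the ring. Also open, on these data alone, is whether 1-methyl-1H-pyrazol-5-yl, which carries a methyl on the ring nitrogen, would read like compound 4.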